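From chloro to methyl on compound 2

A few compounds are considered here, and "the series" means these few. Any claim that something is new, unique, unknown or untested is made for them only; others in the source may bear on it.

For the measured compounds named here, compound 2 `O=C(CN1CCN(C(=O)c2ccc(Cl)cc2)CC1)N1CCN(CCCc2c[nH]c3ccc(F)cc23)CC1` gives 125000 nM in an ADME assay on SH-SY5Y cells (Homo sapiens) for cytotoxicity, read by MTT assay, with a stated time of 72 h (on this read-out higher numbers stand for weaker inhibition and lower numbers for stronger inhibition), and holds the only exact number so far. Compound 1 `Cc1ccc(C(=O)N2CCN(CC(=O)N3CCN(CCCc4c[nH]c5ccccc45)CC3)CC2)cc1` gives > 200000 nM in this assay as a limit of the assay, not a number. Compound 3 `Cc1ccc(C(=O)N2CCN(CC(=O)N3CCN(CCCc4c[nH]c5ccc(F)cc45)CC3)CC2)cc1` alters compound 2 in one place, with methyl in place of chloro on an aromatic carbon as the counted change: methyl in place of chloro on an aromatic carbon, para to a large group. Going by the values given here, no measured pair of compounds shows this swap on its own, so its size has to be judged without a direct precedent. With compound 2 at 125000 nM as the starting point, replacing one heavy atom with one other is expected to shift the value little, if anything slightly upward. The estimated change a 1.2-fold higher number from compound 2 to compound 3 (0.08 log units; within the scatter) is expected to stay within the usual scatter. For compound 3 the expected value is 150000 nM within a range from 80000 nM to 280000 nM in this measurement.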

Compound 3, half-maximal inhibitory concentration: 119000 nM
Beside the measured number, compound 3's estimate is 1.3-fold (0.10 log units) above it; the measured number falls inside the stated range.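

In this assay, methyl in place of chloro at this position, para to a large group, gives a 1.1-fold lower number from compound 2 to compound 3 (0.02 log units; within the scatter), so the 4-chlorophenyl and 4-methylphenyl forms cannot be told apart on this read-out. For the compounds shown here, the compound also gives a first look at fluoro in place of hydrogen on an aromatic carbon, with an at least 1.6-fold lower number from compound 1 to compound 3 (0.22 log units; that floor lies within the scatter), so even the smallest change this step allows cannot be told from scatter. Compound 1 stands at a limit of the assay, not at a number, so this step is only a floor: the limit of > 200000 nM in this assay, at which 1 of the 3 values shown sits.

As far as these compounds go, whether an amine or a carboxylic acid on the same aromatic carbon would move the number beyond the scatter stays open. From the compounds shown here alone, how large the true step from hydrogen to fluoro is also stays open.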